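The source may report more compounds than this note shows. Statements on the series, on what has been measured and on what is new or still open speak of the compounds shown alone.

Compound 1 `O=C(NCN1CCC(c2cccc[n+]2[O-])CC1)c1ccc(F)c(Cl)c1`: 63 nM
Compound 2 `N#Cc1cccc(C(=O)NCN2CCC(c3cccc[n+]3[O-])CC2)c1`: 840 nM
Compound 3 `Cc1ccc(C(=O)NCN2CCC(c3cccc[n+]3[O-])CC2)cc1C(F)(F)F`: 85 nM

All three were measured in a functional assay on HEK293 cells for agonist activity at D(4) dopamine receptor (Homo sapiens), read by FLIPR; a lower number here means that less compound is needed, a higher number that more compound is needed for the effect. Compound 3 stands second highest of the three numbers: compound 1 gives 63 nM, a gap that is within the usual scatter, while compound 2 gives 840 nM, a gap well beyond it. Compound 4 `Cc1ccc(C(=O)NCN2CCC(c3cccc[n+]3[O-])CC2)cc1C` is not yet measured; it differs from compound 3 in one place: methyl in place of trifluoromethyl on an aromatic carbon. Within the data shown here, the only measured step, a 13-fold higher number from compound 1 to compound 2 (1.12 log units; beyond the scatter), concerns other groups on the same aromatic ring, so it bears only loosely here, though it shows that changing groups there can move the number a great deal. Among the measured compounds shown here, with no direct precedent, compound 4 is expected to give 150 nM, between 50 nM and 500 nM. That amounts to an expected 1.8-fold higher number from compound 3 to compound 4 (0.25 log units; within the scatter) in this assay.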

Compound 4, half-maximal effective concentration: 38 nM
For compound 4 the middle estimate is 3.9-fold (0.60 log units) above the measured one; the whole stated range lies above it.
By their numbers in this assay, from the lowest: compounds 4, 1 and 3 (each within the scatter of the next, the first and the last beyond it); then compound 2.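

In this assay, methyl in place of trifluoromethyl on this aromatic carbon gives a 2.2-fold lower number from compound 3 to compound 4 (0.35 log units; beyond the scatter), so a low number here does not depend on the fluorine atoms. The 3,4-dimethylphenyl group stands well apart from the 3-cyanophenyl group, with a 22-fold lower number from compound 2 to compound 4 (1.34 log units; beyond the scatter), but not clearly apart from the 3-chloro-4-fluorophenyl group, with a 1.7-fold lower number from compound 1 to compound 4 (0.22 log units; within the scatter). Nothing available explains these shifts. From the compounds shown here alone, it remains open how an amine, a hydroxyl or a longer chain such as ethyl on this carbon would compare with methyl.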